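This account rests on a few compounds, and the source may have more. Where it says the series, first, only, none or still open, it means among the compounds named here.

Notes on the series. Compound 1 `CN1CCC[C@H]1COc1cccnc1` is the unsubstituted parent; in an assay on K177 cells with Neuronal acetylcholine receptor; alpha4/beta2 (Homo sapiens) as the target (a higher number here means a larger maximal response, a lower number a smaller maximal response), compound 1 gives 100%, the highest of the three numbers at hand. Compound 2 `Cc1ncccc1OC[C@@H]1CCCN1C`, methyl in place of hydrogen on an aromatic carbon, gives 26.7% in this assay; compound 3 `CN1CCC[C@H]1COc1cnccc1Br`, bromo in place of hydrogen on an aromatic carbon, gives 14.1%. Both substitutions lower the maximal response sharply: a number 73.3 percentage points lower from compound 1 to compound 2 (beyond the scatter) and a number 85.9 percentage points lower from compound 1 to compound 3 (beyond the scatter), each beyond the scatter.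

Compound 4 `CCCc1cncc(OC[C@@H]2CCCN2C)c1` is not yet measured. It differs from compound 1 by propyl in place of hydrogen on an aromatic carbon, the propyl sitting on an aromatic carbon of the six-membered aromatic ring with one nitrogen, two atoms from the ring nitrogen and meta to the group of eight heavy atoms. Both measured steps bear on it, since each places a group on an aromatic carbon of the same ring in place of hydrogen, and both were large downward steps. The propyl is expected to act in the same direction, so a large drop is expected: a number 75 percentage points lower from compound 1 to compound 4 (beyond the scatter). Among the measured compounds shown here, compound 4 is accordingly estimated at 25%, with a range of 5% to 60%; since the aromatic carbon carrying the propyl is not the one substituted in compound 2 or compound 3, the range is kept wide.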

Compound 4, largest response reached (reported as maximum), in percent of the reference or control that the assay uses: 13%
The estimate for compound 4 lay 12 percentage points above the measured number; measured number inside the range.
By their numbers in this assay, from the lowest: compounds 4 and 3 (each within the scatter of the next); then compound 2; then compound 1.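

In this assay, the step of a number 87 percentage points lower from compound 1 to compound 4 (beyond the scatter) shows that the large loss of maximal response also occurs when the substituent sits on an aromatic carbon two atoms from the ring nitrogen, meta to the group of 8 heavy atoms. The fall is therefore not confined to the aromatic carbons substituted in compound 2 and compound 3, and none of the substituted compounds shown goes against it. No measurement at hand gives a reason for this loss at the new position.

As far as these compounds go, it remains open whether the loss at this carbon depends on the length of the chain, as a methyl or a butyl chain there would show. Also open, from the compounds shown here alone, is whether a fluoro, an amine or a carboxylic acid on the same carbon would give a similar fall.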